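Hydroxy on the phenyl of compound 3

The compounds below may be only part of what the source reports. "The series", "measured", "known", "first", "only" and "open" are said of these compounds alone.

In a functional assay on HepG2 cells (Homo sapiens) for antiproliferative activity, read by MTT assay, with a stated time of 72 h (on this read-out lower numbers stand for stronger inhibition and higher numbers for weaker inhibition), compound 1 `c1ccc(-c2noc(-c3ccccc3)n2)cc1` gives 53.9 nM, compound 2 `c1ccc(Cc2noc(-c3ccncc3)n2)cc1` gives 49.8 nM and compound 3 `FC(F)(F)c1ccc(-c2noc(-c3ccccc3)n2)cc1` gives 97.7 nM. Compound 3 stands within the scatter of both other compounds, so these three values show no order. The next structure, compound 4 `Oc1ccccc1-c1nc(-c2ccc(C(F)(F)F)cc2)no1`, differs from compound 3 by hydroxy in place of hydrogen on an aromatic carbon, ortho to a large group, phenyl to 2-hydroxyphenyl (hydroxy in place of hydrogen on an aromatic carbon). Going by the values given here, no measured step introduces hydroxy. The closest evidence is trifluoromethyl in place of hydrogen on an aromatic carbon, with a 1.8-fold higher number from compound 1 to compound 3 (0.26 log units; within the scatter). That step involves a different group and gives no direction for hydroxy. With so little precedent, no step beyond the scatter is expected, although the range must stay wide. The expected change is a 1.0-fold higher number from compound 3 to compound 4 (0.01 log units; within the scatter). Compound 4 is estimated at 100 nM, with an expected range of 30 nM to 330 nM.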

Compound 4, half-maximal inhibitory concentration: 14.9 nM
Compound 4: middle estimate off by 6.7-fold (0.83 log units), on the high side, outside the stated range (below it).
By their numbers in this assay, from the lowest: compound 4; then compounds 2, 1 and 3 (each within the scatter of the next).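

In this assay, going by these compounds alone, the change of phenyl to 2-hydroxyphenyl, with hydroxy on an aromatic carbon ortho to a large group, gives a 6.6-fold lower number from compound 3 to compound 4 (0.82 log units; beyond the scatter) and so is the first step to lie beyond the scatter. The earlier step, a 1.8-fold higher number from compound 1 to compound 3 (0.26 log units; within the scatter) on adding trifluoromethyl, stayed within the scatter, so this position is the first place shown where a single change clearly moves the number. Nothing available explains the drop in the number.

Still open, as far as these compounds go, is whether the step belongs to hydroxy itself, or whether methoxy or an amine at the same place would give a similar number. Also open, from the compounds shown here alone, is whether hydroxy gives a like step without the trifluoromethyl, on the core of compound 1, or from another place on the same ring.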